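The source may report more compounds than this note shows. Statements on the series, on what has been measured and on what is new or still open speak of the compounds shown alone.

Measured in a functional assay on Caco-2 cells (Homo sapiens) for cytotoxicity, read by luminescence and CellTiter-Glo, with a stated time of 72 h; a lower number here means a stronger inhibitor, a higher number a weaker inhibitor:
- compound 1 `O=C1C=CC[C@@H]([C@H](O)[C@H](O[C@@H](c2ccccc2)[C@@H](O)[C@@H]2CC=CC(=O)O2)c2ccccc2)O1`: > 10000 nM (a limit)
- compound 2 `O=C1C=CC[C@@H]([C@H](O)[C@@H](O[C@H]([C@@H]2CC=CC(=O)O2)[C@@H](O)c2ccccc2)c2ccccc2)O1`: > 10000 nM (a limit)

Compound 1 gives no number, only the limit > 10000 nM. Among the measured compounds shown here, the series so far stands at the limit of > 10000 nM in this assay, at which 2 of the 2 values shown sit. Compound 3 `CC(=O)O[C@@H]([C@@H]1CC=CC(=O)O1)[C@H](O[C@@H](c1ccccc1)[C@@H](O)[C@@H]1CC=CC(=O)O1)c1ccccc1` carries one change from compound 1: acetyl in place of hydrogen on an oxygen on a saturated carbon. For the measured compounds named here, no measured step is available as a guide, so no step beyond the scatter is expected in this assay, and another limit is likely. The expected step is a number no higher from compound 1 to compound 3 (the limit leaves the size open). For compound 3 the estimated value is 10000 nM, with an expected range of 3000 nM to 20000 nM.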

Compound 3, half-maximal inhibitory concentration: 7000 nM
Compound 3: middle estimate off by 1.4-fold (0.15 log units), on the high side, within the range that was stated.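

Acetoxy in place of hydroxy on this oxygen gives the first actual number in this assay, with compound 3 at 7000 nM. From the compounds shown here alone, the step reads an at least 1.4-fold lower number from compound 1 to compound 3 (0.15 log units; that floor lies within the scatter), and its full size stays unknown. Compound 1 remains a limit, as does most of the series: the limit of > 10000 nM in this assay, at which 2 of the 3 values shown sit.

Open, going by these compounds, is whether a longer acyl chain such as butyryl, or a methyl ether, on this oxygen would also give a number rather than a limit. Also open, on these data alone, is what an acetyl on the free hydroxy of compound 3 would do.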